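A few compounds are considered here, and "the series" means these few. Any claim that something is new, unique, unknown or untested is made for them only; others in the source may bear on it.

Measured so far:
compound 1 `O=C1N=C(N2CCC[C@H]2C(=O)Nc2ccc3ncnc(Nc4cccc(Cl)c4)c3c2)S/C1=C/c1ccccc1Cl`: 28100 nM
compound 2 `O=C1N=C(N2CCC[C@H]2C(=O)Nc2ccc3ncnc(Nc4cccc(Cl)c4)c3c2)S/C1=C/c1cccc(Br)n1`: 2700 nM

Among the measured compounds shown here, in a functional assay on HepG2 cells (Homo sapiens) for antiproliferative activity, read by MTT assay (a lower number here means a stronger inhibitor, a higher number a weaker inhibitor), compound 2 stands lowest of the two numbers; the only neighbour is compound 1, and a 10-fold lower number from compound 1 to compound 2 (1.02 log units; beyond the scatter). Compound 3 `O=C1N=C(N2CCC[C@H]2C(=O)Nc2ccc3ncnc(Nc4cccc(Cl)c4)c3c2)S/C1=C/c1cccnc1Cl` differs from compound 2 by 2-chloropyridin-3-yl in place of 6-bromopyridin-2-yl on a double-bonded chain carbon bound to a double-bonded ring carbon. For the measured compounds named here, only the one measured step bears on this change, and it does not test the same exchange: it swapped an aryl group for a pyridyl group, whereas here one pyridyl gives way to another. Compound 3 keeps the ring nitrogen of compound 2 but carries a chlorine like compound 1. A modest weakening is therefore expected, a 2.6-fold higher number from compound 2 to compound 3 (0.41 log units; beyond the scatter), not confidently beyond the scatter. For compound 3 the estimate is 7000 nM, expected between 2000 nM and 25000 nM.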

Compound 3, half-maximal inhibitory concentration: 6400 nM
Beside the measured number, compound 3's estimate is 1.1-fold (0.04 log units) above it; low and high end bracket the measured number.
By their numbers in this assay, from the lowest: compound 2; then compound 3; then compound 1.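

At this position, in this assay, a second pyridyl group also improves on 2-chlorophenyl, with a 4.4-fold lower number from compound 1 to compound 3 (0.64 log units; beyond the scatter), so the gain is not confined to 6-bromopyridin-2-yl. The two pyridyl groups still differ, with a 2.4-fold higher number from compound 2 to compound 3 (0.37 log units; beyond the scatter), but this exchange changes the halogen and the places of both the ring nitrogen and the halogen at once, so no single change can be credited. Nothing available explains these differences.

On these data alone, whether the pyridyl ring needs a halogen at all remains open, as does how a methoxy group or an amine would compare in its place.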